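Chloro to phenyl on the shared core: compound 3

A few compounds are considered here, and "the series" means these few. Any claim that something is new, unique, unknown or untested is made for them only; others in the source may bear on it.

Measured so far:
Compound 2 `O=C(Nc1cc(C(F)(F)F)cc(C(F)(F)F)c1)c1cnc(Cl)nc1` gives 300 nM in an assay on Jurkat cells for activation of nuclear factor NF-kappa-B complex (Homo sapiens); a lower number here means a stronger inhibitor, a higher number a weaker inhibitor.
Compound 1 `CCc1nc(Cl)ncc1C(=O)Nc1cc(C(F)(F)F)cc(C(F)(F)F)c1` gives 400 nM in this assay.

Compound 2 holds the lower of the two numbers, but compound 1 lies within the scatter of it, so the two stand together. For the measured compounds named here, the only measured step, a 1.3-fold lower number from compound 1 to compound 2 (0.12 log units; within the scatter), concerns hydrogen in place of ethyl and is within the scatter.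

Compound 3 `O=C(Nc1cc(C(F)(F)F)cc(C(F)(F)F)c1)c1cnc(-c2ccccc2)nc1` carries phenyl in place of chloro on an aromatic carbon, between two ring nitrogen atoms and para to a large group. Going by the values given here, no measured step touches this position or exchanges chloro for a ring, so the step of a 1.3-fold lower number from compound 1 to compound 2 (0.12 log units; within the scatter) bears on it only as a sign that the one change tried on the core left the number where it was. Nothing supports a shift beyond the scatter in either direction in this assay.

Compound 3 is therefore estimated at 300 nM, range 60 nM to 1500 nM, an expected step of no change at the digits printed from compound 2 to compound 3 (within the scatter).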

Compound 3, half-maximal inhibitory concentration: > 10000 nM
Compound 3: only a limit was reported; the forecaster's own chance of this, stated with the estimate: 5%; middle value at least 33-fold (1.52 log units) from the limit.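

In this assay, phenyl in place of chloro gives an at least 33-fold higher number from compound 2 to compound 3 (1.52 log units; beyond the scatter), the only step shown that lies beyond the scatter. For the compounds shown here, compound 3 is recorded as > 10000 nM, which is a limit and not a number, so the full size of the step stays unknown: the limit of > 10000 nM in this assay, at which 1 of the 3 values shown sits. This position, on an aromatic carbon between two ring nitrogen atoms, therefore responds strongly to this exchange, something the only earlier step, a 1.3-fold lower number from compound 1 to compound 2 (0.12 log units; within the scatter), which concerns hydrogen in place of ethyl, gave no sign of.

The compounds shown leave open whether the loss goes with the entering phenyl ring or with the departure of chloro. A smaller group at this position, such as methyl, methoxy or an amine, would separate the two readings.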